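Chloro for methoxy on the benzofuran-linked phenyl ring

The source may report more compounds than this note shows. Statements on the series, on what has been measured and on what is new or still open speak of the compounds shown alone.

Measured compounds:
compound 1 `Cn1cncc1C(O)(c1ccc(C#N)cc1)c1cc2cc([N+](=O)[O-])cc(-c3ccccc3)c2o1`: 1480 nM
compound 2 `COc1ccc(C(O)(c2cc3cc([N+](=O)[O-])cc(-c4ccccc4)c3o2)c2cncn2C)cc1`: 4970 nM
compound 3 `Cn1cncc1C(O)(c1ccc(C#N)cc1)c1cc2cc([N+](=O)[O-])cc(-c3cccc(C#N)c3)c2o1`: 22.9 nM

In a functional assay on QG-56 cells (Homo sapiens) for antiproliferative activity (a lower number here means a stronger inhibitor, a higher number a weaker inhibitor), compound 2 gives the highest number of the three, with compound 1 a 3.4-fold higher number from compound 1 to compound 2 (0.53 log units; beyond the scatter) nearest and compound 3 far stronger after a 65-fold lower number from compound 1 to compound 3 (1.81 log units; beyond the scatter). Compound 4 `Cn1cncc1C(O)(c1ccc(Cl)cc1)c1cc2cc([N+](=O)[O-])cc(-c3ccccc3)c2o1` differs from compound 2 by chloro in place of methoxy on an aromatic carbon. Among the compounds with values here, only the step from compound 1 to compound 2 touches this position: replacing cyano by methoxy there raised the number modestly. Within the data shown here, no measured step shows chloro at that place, so the direction is inferred only from cyano being better than methoxy. Compound 4 is therefore expected to come out somewhat lower than compound 2, by about a 2.3-fold lower number from compound 2 to compound 4 (0.35 log units; beyond the scatter). The estimated value for compound 4 is 2200 nM, within 800 nM to 5500 nM.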

Compound 4, half-maximal inhibitory concentration: 1890 nM
Compound 4: middle estimate off by 1.2-fold (0.07 log units), on the high side; the measured number falls inside the stated range.
By their numbers in this assay, from the lowest: compound 3; then compounds 1 and 4 (each within the scatter of the next); then compound 2.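

In this assay, within the data shown here, the change from 4-methoxyphenyl to 4-chlorophenyl gives a 2.6-fold lower number from compound 2 to compound 4 (0.42 log units; beyond the scatter), while chloro and cyano at this place cannot be told apart, with a 1.3-fold higher number from compound 1 to compound 4 (0.11 log units; within the scatter); the earlier compounds set only cyano against methoxy here, so methoxy now stands apart from two other groups. No measurement shown here accounts for these differences. Open, as far as these compounds go, is how an amine or a carboxylic acid at this place would compare. Also open, from the compounds shown here alone, is whether chloro and cyano would still match on the core of compound 3.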